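Propyl to 4-fluorophenyl on the shared core

The source may hold more compounds than are shown below. What is called first, only, known or untested is meant among the compounds shown, and "the series" means these compounds.

In a functional assay on HCT-116 cells (Homo sapiens) for cytotoxicity, read by MTT assay, with a stated time of 48 h, in the presence of a further agent that is not named here (on this read-out lower numbers stand for an effect already at smaller amounts and higher numbers for an effect only at larger amounts of compound), compound 1 (`Cn1ncc2c(-c3ccc(F)cc3)cc(NNC(=O)Nc3cc(Cl)cc(Cl)c3)nc21`) gives 39100 nM and compound 2 (`CCCc1cc(NNC(=O)Nc2cc(Cl)nc(Cl)c2)nc2c1cnn2C`) gives 76200 nM on the same read-out. These two numbers lie within the scatter of each other, so compound 2 stands level with compound 1 and the pair sets no order.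

Compound 3 (`Cn1ncc2c(-c3ccc(F)cc3)cc(NNC(=O)Nc3cc(Cl)nc(Cl)c3)nc21`), still unmeasured, has 4-fluorophenyl in place of propyl on an aromatic carbon of compound 2, opposite the ring nitrogen. Within the data shown here, no measured pair differs in one place only, so this change has no direct precedent. The expectation rests on the two numbers alone, compound 1 at 39100 nM and compound 2 at 76200 nM being all that is known so far.

No shift beyond the scatter is expected in this assay, with a slight lean toward a lower number. The estimated step of a 1.7-fold lower number from compound 2 to compound 3 (0.23 log units; within the scatter) is expected to stay within the scatter. In this assay the estimated value for compound 3 is 45000 nM with an expected range from 18000 nM to 100000 nM overall.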

Compound 3, half-maximal effective concentration: 8210 nM
The estimate for compound 3 lay 5.5-fold (0.74 log units) above the measured number; the whole stated range lies above it.
By their numbers in this assay, from the lowest: compound 3; then compounds 1 and 2 (each within the scatter of the next).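

In this assay, 4-fluorophenyl in place of propyl on the aromatic carbon opposite the ring nitrogen gives a clear step (a 9.3-fold lower number from compound 2 to compound 3 (0.97 log units; beyond the scatter)), so this position responds to the group it carries when 2,6-dichloropyridin-4-yl is held constant. With 4-fluorophenyl held constant, 2,6-dichloropyridin-4-yl in place of 3,5-dichlorophenyl on an amide-type nitrogen also gives a step beyond the scatter (a 4.8-fold lower number from compound 1 to compound 3 (0.68 log units; beyond the scatter)), so each of the two single changes now has a measured size, which compound 1 and compound 2, differing in more than one place, could not provide. Nothing available here bears on what lies behind either step.

At the aromatic carbon, only propyl and 4-fluorophenyl can be compared so far, which leaves open how a methyl, an amine, a carboxylic acid or an unsubstituted phenyl would read on the shared core. Also open is whether the step from propyl to 4-fluorophenyl keeps its size with 3,5-dichlorophenyl on the amide-type nitrogen, since the propyl partner carrying that group is absent from the compounds shown.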